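This account rests on a few compounds, and the source may have more. Where it says the series, first, only, none or still open, it means among the compounds named here.

Measured compounds:
- Compound 1 `Cc1ccc(S(=O)(=O)Nc2ccc(CNC(=O)CC3c4ccccc4N=C(N4CCCCC4)N3c3ccccc3)cc2)cc1`: 2700 nM
- Compound 2 `COC(=O)CC1c2ccccc2N=C(NCCCCCN)N1c1ccc(-c2ccccc2)cc1`: 3320 nM

In a functional assay on SK-MEL-2 cells (Homo sapiens) for inhibition, read by sulforhodamine B assay (a higher number here means a weaker inhibitor of growth, a lower number a stronger inhibitor of growth), compound 1 gives 2700 nM, the lower of the two numbers, though its gap to compound 2 at 3320 nM lies within the usual scatter, so neither can be called the stronger one. Compound 3 `CCN1C(N2CCCCC2)=Nc2ccccc2C1CC(=O)NCc1ccc(NS(=O)(=O)c2ccc(C)cc2)cc1` differs from compound 1 in one place: ethyl in place of phenyl on an amine nitrogen in a ring. Within the data shown here, no measured pair shows what such a change does here, so only a guess is possible. A small step is expected, towards a weaker inhibitor of growth, with the estimated shift from compound 1 to compound 3 being a 1.7-fold higher number from compound 1 to compound 3 (0.22 log units; within the scatter). For compound 3 the estimate is 4500 nM, between 1500 nM and 13000 nM.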

Compound 3, concentration for 50% growth inhibition: 3520 nM
Compound 3: middle estimate off by 1.3-fold (0.11 log units), on the high side, within the range that was stated.
By their numbers in this assay, from the lowest: compounds 1, 2 and 3 (each within the scatter of the next).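

In this assay, replacing phenyl with the much smaller ethyl on this amine nitrogen in a ring gives a 1.3-fold higher number from compound 1 to compound 3 (0.12 log units; within the scatter). The aromatic ring at this position is therefore not needed to keep growth inhibition at this level, and the two groups cannot be told apart here. Nothing available explains this outcome. As far as these compounds go, it remains open whether a longer chain such as hexyl would fit equally well at this position, or whether a chain ending in an amine or a carboxylic acid would shift the number.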